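The compounds below may be only part of what the source reports. "The series", "measured", "known", "first", "only" and "open" are said of these compounds alone.

Measured so far:
- Compound 1, `COc1ccc(-c2cnc3nc(N)nc(N4CCC(C)CC4)c3n2)cc1OC`, gives 800 nM.
- Compound 2, `COc1ccc(-c2cnc3nc(N)nc(OC(C)C)c3n2)cc1`, gives only a limit, > 10000 nM.
- Compound 3, `COc1ccc(-c2cnc3nc(N)nc(N4CCN(C(=O)Nc5ccccc5)CC4)c3n2)cc1OC`, gives 3.4 nM.

Of the compounds shown here, three sharing one core have been tested in a functional assay on cells (T-cell, Homo sapiens) for inhibition; on this read-out higher numbers stand for weaker inhibition and lower numbers for stronger inhibition. Compound 3 stands lowest of the two real numbers, and the gap to compound 1 is far beyond the usual scatter. Compound 2 reaches only (the limit of > 10000 nM in this assay, at which 1 of the 3 values shown sits), so it yields no number to compare.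

Compound 4, `COc1ccc(-c2cnc3nc(N)nc(N4CCN(C(=O)COc5ccc(Cl)cc5)CC4)c3n2)cc1OC`, differs from compound 3 in a single place: (4-chlorophenoxy)methyl in place of anilino on a carbonyl carbon. The anilino group carried one hydrogen-bond donor; the (4-chlorophenoxy)methyl group carries none and brings one hydrogen-bond acceptor instead, so the urea-like link becomes an amide.

Within the data shown here, no measured pair shows a change of this kind, so its effect cannot be read from the data. The expectation is that compound 4 keeps most of the strength of compound 3, with a modest loss. Compound 4 is expected to give about 10 nM, between 2 nM and 60 nM. That estimate corresponds to an expected step of a 2.9-fold higher number from compound 3 to compound 4 (0.47 log units; beyond the scatter), close to the edge of the scatter.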

Compound 4, half-maximal inhibitory concentration: 0.5 nM
For compound 4 the middle estimate is 20-fold (1.30 log units) above the measured one, outside the stated range (below it).
By their numbers in this assay, from the lowest: compound 4; then compound 3; then compound 1. At a limit, above all of these: compound 2.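

On a carbonyl carbon whose other neighbour is an amide-type nitrogen in a ring, the anilino group is not needed for strength in this assay: (4-chlorophenoxy)methyl in its place gives a 6.8-fold lower number from compound 3 to compound 4 (0.83 log units; beyond the scatter). In this pair, the hydrogen-bond donor of the anilino group can be lost without any loss of strength, and the urea-like link can become an amide. No measurement shown here explains why this step goes in this direction.

As far as these compounds go, it remains open which part of the new group matters: the chlorine, the ether oxygen or the added carbon. A plain phenoxymethyl group, without the chlorine, or a benzyl group, without the oxygen, on the same carbonyl carbon would help to separate these parts.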